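From pyrimidin-2-yl to oxan-4-yl on compound 3

This account rests on a few compounds, and the source may have more. Where it says the series, first, only, none or still open, it means among the compounds named here.

In a physicochemical assay for solubility, read by LC-MS, in phosphate buffer, with a stated time of 24 h, at pH 6.8 (on this read-out higher numbers stand for higher solubility and lower numbers for lower solubility), compound 3 `C[C@H](NC(=O)c1ncccn1)c1ccc(NC(=O)N2CC(c3cncc(N)c3)C2)cc1` gives 300000 nM. That lies within the scatter of compound 1 `C[C@H](NC(=O)C1CCOCC1)c1ccc(NC(=O)N2CC(c3cccnc3)C2)cc1` at 380000 nM, and far from compound 2 `C[C@H](NC(=O)c1cccc(F)c1)c1ccc(NC(=O)N2CC(c3cncc(N)c3)C2)cc1` at 17000 nM. Compound 4 `C[C@H](NC(=O)C1CCOCC1)c1ccc(NC(=O)N2CC(c3cncc(N)c3)C2)cc1` carries oxan-4-yl in place of pyrimidin-2-yl on a carbonyl carbon. For the measured compounds named here, the one measured step at this place, an 18-fold higher number from compound 2 to compound 3 (1.25 log units; beyond the scatter), was large, but it replaced 3-fluorophenyl, not oxan-4-yl, so it says little here. Compound 1 already carries oxan-4-yl, differs elsewhere, and gives 380000 nM, close to the value of compound 3. No shift beyond the scatter is therefore expected in this assay, and the expected step is no change at the digits printed from compound 3 to compound 4 (within the scatter). For compound 4 the estimated value is 300000 nM, with an expected range from 120000 nM to 600000 nM.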

Compound 4, solubility: 440000 nM
Beside the measured number, compound 4's estimate is 1.5-fold (0.17 log units) below it, within the range that was stated.
By their numbers in this assay, from the lowest: compound 2; then compounds 3, 1 and 4 (each within the scatter of the next).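

Putting oxan-4-yl in place of pyrimidin-2-yl on a carbonyl carbon gives a 1.5-fold higher number from compound 3 to compound 4 (0.17 log units; within the scatter) in this assay so these two rings read alike here. Oxan-4-yl in place of 3-fluorophenyl gives a 26-fold higher number from compound 2 to compound 4 (1.41 log units; beyond the scatter) and leaves 3-fluorophenyl as the one group of the three that stands apart at this position. With oxan-4-yl present, amino in place of hydrogen on an aromatic carbon gives a 1.2-fold higher number from compound 1 to compound 4 (0.06 log units; within the scatter) so that second change leaves the number within the scatter. Nothing available explains these results. Open, going by these compounds, is whether a longer chain or a ring carrying a carboxylic acid at this carbonyl carbon would stay with compound 3 and compound 4 or drop towards compound 2.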